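From a Basic Amine to an Acetamide on the Aryl Arm

The compounds below may be only part of what the source reports. "The series", "measured", "known", "first", "only" and "open" are said of these compounds alone.

Compound 3 `CN(C)Cc1ccc(-c2c3ncn(CC4(O)CCN(Cc5ccc(-c6ccco6)cc5Cl)CC4)c(=O)c3nn2C)cc1` gives 131 nM in an assay on isolated protein for inhibition of ubiquitin carboxyl-terminal hydrolase 7 (Homo sapiens), with stated times of 30 min and 2 h (a higher number here means a weaker inhibitor, a lower number a stronger inhibitor), the second highest of the three measured numbers. Its nearest neighbour is compound 2 `Cn1nc2c(=O)n(CC3(O)CCN(Cc4ccc(-c5ccco5)cc4Cl)CC3)cnc2c1-c1ccc(C(N)=O)cc1`, which gives 80.8 nM in this assay; the step of a 1.6-fold higher number from compound 2 to compound 3 (0.21 log units; within the scatter) lies within the scatter. Furthest away is compound 1 `Cn1nc2c(=O)n(CC3(O)CCN(Cc4ccc(-c5ccco5)cc4Cl)CC3)cnc2c1-c1ccc(CNC(=O)C(F)(F)F)cc1`, which gives 2060 nM in this assay, and the step of a 16-fold lower number from compound 1 to compound 3 (1.20 log units; beyond the scatter) is large.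

The unmeasured compound 4 `CC(=O)NCc1ccc(-c2c3ncn(CC4(O)CCN(Cc5ccc(-c6ccco6)cc5Cl)CC4)c(=O)c3nn2C)cc1` differs from compound 3 in one place: acetamido in place of dimethylamino on a saturated chain carbon bound to an aromatic carbon. For the measured compounds named here, two measured steps bear on this change. The step of a 16-fold lower number from compound 1 to compound 3 (1.20 log units; beyond the scatter) shows that going from an amide bearing trifluoromethyl to dimethylamino at this carbon lowered the number strongly, and compound 4 moves back toward an amide. The step of a 25-fold lower number from compound 1 to compound 2 (1.41 log units; beyond the scatter) shows that carbamoyl on the aromatic carbon also lowered the number strongly. Going by the values given here, no measured pair separates the trifluoromethyl from the amide itself, so the size of the return is uncertain. A step upward beyond the scatter in this assay is expected from compound 3 to compound 4, estimated as a 5.3-fold higher number from compound 3 to compound 4 (0.73 log units; beyond the scatter), because the step of a 16-fold lower number from compound 1 to compound 3 (1.20 log units; beyond the scatter) ran in the opposite direction. Compound 4 is therefore estimated at 700 nM in this assay, with a range from 200 nM to 2500 nM.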

Compound 4, half-maximal inhibitory concentration: 46.1 nM
The estimate for compound 4 lay 15-fold (1.18 log units) above the measured number; the measured number lies below the stated range.
By their numbers in this assay, from the lowest: compounds 4, 2 and 3 (each within the scatter of the next, the first and the last beyond it); then compound 1.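

For the compounds shown here, the step of a 45-fold lower number from compound 1 to compound 4 (1.65 log units; beyond the scatter) in this assay exchanges only trifluoromethyl for methyl on the carbonyl carbon, so it isolates what the earlier pairs could not: the large gap lies with that exchange, not with the presence of an amide at this carbon. An amide here is therefore compatible with a low number, and the step of a 2.8-fold lower number from compound 3 to compound 4 (0.45 log units; beyond the scatter) shows that acetamido in place of dimethylamino on the saturated chain carbon gives a modest change beyond the scatter, opposite in direction to what the step from the trifluoroacetamide suggested. The step of a 1.8-fold lower number from compound 2 to compound 4 (0.24 log units; within the scatter) lies within the scatter, so acetamidomethyl and carbamoyl on the aromatic carbon cannot be told apart in this assay.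

The compounds shown leave open how the number responds between the two extremes on the carbonyl carbon, as with monofluoromethyl, difluoromethyl or a longer chain such as ethyl. They also leave open what a free primary amine, a sulfonamide or a methyl on the amide nitrogen would do at this carbon. No measurement shown gives a reason for these differences.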